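Notes on the step from methoxy to acetamido

The source may report more compounds than this note shows. Statements on the series, on what has been measured and on what is new or still open speak of the compounds shown alone.

Values in a functional assay on HCT-116 cells (Homo sapiens) for antiproliferative activity; a higher number here means that more compound is needed for the effect, a lower number that less compound is needed:
- compound 1 `COCCN1CC[C@H](C)Nc2cc(ccc2C(N)=O)-n2c(c(C)c3c2CC(C)(C)CC3=O)CC1=O`: 359 nM
- compound 2 `CC(=O)N1CCc2c(C)c3c(n2-c2ccc(C(N)=O)c(c2)N[C@@H](C)CC1)CC(C)(C)CC3=O`: 151 nM
- compound 3 `Cc1c2c(n3c1CCN(C(=O)[C@@H](C)N)CC[C@H](C)Nc1cc-3ccc1C(N)=O)CC(C)(C)CC2=O`: 710 nM
- compound 4 `CC(=O)NCCN1CC[C@H](C)Nc2cc(ccc2C(N)=O)-n2c(c(C)c3c2CC(C)(C)CC3=O)CC1=O`: not yet measured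

Compound 1 at 359 nM lies within the scatter of compound 3 at 710 nM. Compound 2 at 151 nM gives a lower number than compound 1, and that gap lies beyond the scatter.

Compound 4 differs from compound 1 by acetamido in place of methoxy on a saturated chain carbon, two bonds along the chain from an amide-type nitrogen in a ring. Among the measured compounds shown here, no measured step covers this chain. The only one available is a 4.7-fold higher number from compound 2 to compound 3 (0.67 log units; beyond the scatter), a modest step with 1-aminoethyl in place of methyl on a carbonyl carbon. It is a different change at a different place, so it gives only a rough guide to size and a weak hint of direction.

In this assay, a small rise is therefore expected, most likely within the scatter and smaller than that modest step. The expected change is a 1.3-fold higher number from compound 1 to compound 4 (0.10 log units; within the scatter). The estimated value for compound 4 is 450 nM. The expected range for compound 4 runs from 170 nM to 1200 nM.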

Compound 4, half-maximal effective concentration in the HCT-116 assay: > 5000 nM
Compound 4 ended at the assay's limit; the forecaster's own chance of this, stated with the estimate: 2%; middle value at least 11-fold (1.04 log units) from the limit.
By their numbers in the HCT-116 assay, from the lowest: compound 2; then compounds 1 and 3 (each within the scatter of the next). At a limit, above all of these: compound 4.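

In the HCT-116 assay, acetamido in place of methoxy on a saturated chain carbon, two bonds along the chain from an amide-type nitrogen in a ring, gives an at least 13-fold higher number from compound 1 to compound 4 (1.14 log units; beyond the scatter), so this chain position is far from indifferent to the group it carries, and 2-acetamidoethyl cannot stand in for 2-methoxyethyl here. Going by these compounds, in the HCT-116 assay compound 4 gives > 5000 nM, which is a limit of the assay and not a number, so the full size of the step stays unknown. In a physicochemical assay for solubility (a higher number here means a more soluble compound, a lower number a less soluble compound), compound 1 gives > 100 ug/mL, which is a limit of the assay and not a number. In the physicochemical assay compound 4 gives > 100 ug/mL, which is also a limit of the assay and not a number. The step from compound 1 to compound 4 cannot be read in the physicochemical assay, where both compounds sit at the limit: the limit of > 100 ug/mL in the physicochemical assay, at which 2 of the 2 values shown sit.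

The compounds shown do not separate the effect of the extra hydrogen-bond donor in acetamido from that of its extra heavy atoms, so an N-methylacetamido group, which has no amide hydrogen, would be informative at this carbon. On these data alone, what a dimethylamino group, a carboxylic acid or a longer ether chain would do at the same place also remains open.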